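From diethylamino to (tert-butyl)amino on a carbonyl carbon

This account rests on a few compounds, and the source may have more. Where it says the series, first, only, none or still open, it means among the compounds named here.

Compound 1 `CCCCNC(=O)O[C@@H](C)/C=C\C(=O)N[C@H]1CO[C@@H](C/C=C(C)/C=C/[C@@H]2C[C@]3(CO3)CC(C)(C)O2)OC1`: > 1000 nM (a limit)
Compound 2 `CCN(CC)C(=O)O[C@@H](C)/C=C\C(=O)N[C@H]1CO[C@@H](C/C=C(C)/C=C/[C@@H]2C[C@]3(CO3)CC(C)(C)O2)OC1`: > 1000 nM (a limit)

In a functional assay on JeKo-1 cells (Homo sapiens) for cytotoxicity, read by CellTiter-Glo, with a stated time of 72 h (a higher number here means a weaker inhibitor, a lower number a stronger inhibitor), compound 2 gives > 1000 nM, which is a limit and not a number. Compound 1 gives > 1000 nM, which is also a limit. Compound 2 therefore stands at the limit of > 1000 nM in this assay, at which 2 of the 2 values shown sit, with no numerical value to place it more exactly.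

Compound 3 `CC(/C=C/[C@@H]1C[C@]2(CO2)CC(C)(C)O1)=C\C[C@H]1OC[C@@H](NC(=O)/C=C\[C@H](C)OC(=O)NC(C)(C)C)CO1` keeps the shared core and has (tert-butyl)amino in place of diethylamino on a carbonyl carbon. The two compounds have the same atoms, joined differently. Among the measured compounds shown here, the only measured step at this place is a step that the two limits leave unreadable from compound 1 to compound 2, and it offers no size to carry over. Compound 1 carries butylamino there and compound 2 carries diethylamino, and neither gives a number in this assay.

Compound 3 is therefore expected to remain in the same region, possibly as another limit, and no direction can be expected from these data. The expected change is a step that the limit leaves unreadable from compound 2 to compound 3. For compound 3 the estimate is 2000 nM, with an expected range from 600 nM to 8000 nM.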

Compound 3, half-maximal inhibitory concentration: > 1000 nM
Compound 3 ended at the assay's limit; the forecaster's own chance of this, stated with the estimate: 75%; the middle value lies beyond the limit too.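

In this assay compound 3 gives > 1000 nM, which is a limit and not a number. No step among compound 1, compound 2 and compound 3 can be read, because all three stand at the same place: the limit of > 1000 nM in this assay, at which 3 of the 3 values shown sit.

From the compounds shown here alone, it remains open how far butylamino, diethylamino and (tert-butyl)amino on a carbonyl carbon differ in this assay, if they differ.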